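The compounds below may be only part of what the source reports. "The series", "measured", "known", "first", "only" and "open" are said of these compounds alone.

Compound 1, `CCCNC(=O)c1cccc(C#Cc2ccccc2Nc2ncnc3ccc(Cl)nc23)c1`, gives 3900 nM in an assay on isolated protein for inhibition of MAP kinase-interacting serine/threonine-protein kinase 2 (Homo sapiens), read by HTRF, in the presence of a further agent that is not named here; a lower number here means a stronger inhibitor, a higher number a weaker inhibitor.
Compound 2, `O=C(c1cccc(C#Cc2ccccc2Nc2ncnc3ccc(Cl)nc23)c1)N1CCOCC1`, gives > 10000 nM in this assay, which is a limit of the assay and not a number.
Compound 3, `CNC(=O)c1oc2ccc(Nc3ncnc4ccc(Cl)nc34)cc2c1C`, gives 2500 nM in this assay.

Compound 3 thus stands at the lowest of the two numbers in this assay, with compound 1 within the scatter of it and compound 2 known only as a limit. Compound 4, `Cc1c(C(=O)N2CCNCC2)oc2ccc(Nc3ncnc4ccc(Cl)nc34)cc12`, differs from compound 3 by piperazin-1-yl in place of methylamino on a carbonyl carbon. Among the measured compounds shown here, the only measured step that bears on this change is an at least 2.5-fold higher number from compound 1 to compound 2 (0.40 log units; beyond the scatter), where morpholin-4-yl replaced propylamino on a carbonyl carbon; its true size is unknown because of the limit of > 10000 nM in this assay, at which 1 of the 3 values shown sits. Compound 3 to compound 4 likewise puts a ring-closed nitrogen substituent in place of an open alkylamino on the carbonyl carbon, so a weaker inhibitor is expected, the step being estimated as a 3.2-fold higher number from compound 3 to compound 4 (0.51 log units; beyond the scatter). Compound 4 is therefore expected to give about 8000 nM in this assay, within a range of 3000 nM to 25000 nM.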

Compound 4, half-maximal inhibitory concentration: 1900 nM
The estimate for compound 4 lay 4.2-fold (0.62 log units) above the measured number; the measured number lies below the stated range.
By their numbers in this assay, from the lowest: compounds 4, 3 and 1 (each within the scatter of the next, the first and the last beyond it). At a limit, above all of these: compound 2.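

On the carbonyl carbon of the compound 3 core, the six-membered ring of piperazin-1-yl can stand in place of methylamino with no change that can be read in this assay: a 1.3-fold lower number from compound 3 to compound 4 (0.12 log units; within the scatter). A ring-closed group on a carbonyl carbon therefore does not always go with a higher number, and compound 2 remains the case against any such rule, with an at least 2.5-fold higher number from compound 1 to compound 2 (0.40 log units; beyond the scatter). That earlier step differs in both its groups and its core, and its true size cannot be read: the limit of > 10000 nM in this assay, at which 1 of the 4 values shown sits.

The compounds shown leave open whether morpholin-4-yl on the core of compound 3 would match piperazin-1-yl or follow the step seen with compound 2. They also leave open whether a longer amine chain or a carboxylic acid on this carbonyl carbon would move the number beyond the scatter.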